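Furan for Phenyl in a Series Without Measured Activity

A few compounds are considered here, and "the series" means these few. Any claim that something is new, unique, unknown or untested is made for them only; others in the source may bear on it.

Measured compounds:
compound 1, `Cn1nccc1-c1cccc2c1CCCN2c1ccc(C#N)c(C(F)(F)F)c1`, > 30000 nM
compound 2, `CCN(c1ccc(C#N)c(Cl)c1)c1cc(-c2ccccc2)ccc1C`, > 30000 nM
compound 3, `CCN(c1cccc(-n2ccnc2)c1)c1ccc(C#N)c(C(F)(F)F)c1`, > 30000 nM

In a functional assay on VCaP cells (Homo sapiens) for antiproliferative activity, read by CCK-8 assay, with a stated time of 6 days (on this read-out lower numbers stand for stronger inhibition and higher numbers for weaker inhibition), compound 2 gives > 30000 nM, and this value is a limit of the assay rather than a number. For the measured compounds named here, the same holds for every value in this set: all three sit at the limit of > 30000 nM in this assay, at which 3 of the 3 values shown sit, so no compound here shows a measured number at all.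

Compound 4, `CCN(c1ccc(C#N)c(Cl)c1)c1cc(-c2ccoc2)ccc1C`, has not yet been measured. It differs from compound 2 in one place (furan-3-yl in place of phenyl on an aromatic carbon). Going by the values given here, with every neighbour at the limit, there is no measured step on which to base a direction. The expected change a number no higher from compound 2 to compound 4 (the limit leaves the size open) is none beyond the scatter. Compound 4 is expected to give about 30000 nM, between 8000 nM and 100000 nM, most likely again only as a limit.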

Compound 4, half-maximal inhibitory concentration: 4010 nM
Compound 4: middle estimate off by 7.5-fold (0.87 log units), on the high side; measured number outside the range, below it.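

In this assay, for the compounds shown here, furan-3-yl in place of phenyl on this aromatic carbon gives an at least 7.4-fold lower number from compound 2 to compound 4 (0.87 log units; beyond the scatter) and provides the first measured number in the set. Going by these compounds alone, the position, para to a methyl group, therefore responds to the group it carries, which the earlier compounds could not show. From the compounds shown here alone, compound 2 gives only a limit, so the full size of the step stays unknown: the limit of > 30000 nM in this assay, at which 3 of the 4 values shown sit.

Going by these compounds, whether furan-3-yl would act the same way on the cores of compound 1 or compound 3 remains open. So does the effect of an amine or a carboxylic acid at this position.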